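Benzyloxy Ring Substituent Swap on a Shared Urea Core

The source may hold more compounds than are shown below. What is called first, only, known or untested is meant among the compounds shown, and "the series" means these compounds.

Compound 2 `Cc1ccc(NC(=O)NC(=O)c2ccc(OCc3cccc(C(F)(F)F)c3)cc2)cc1-c1nc2ccccc2[nH]1` gives 3520 nM in a functional assay on HT-29 cells (Homo sapiens) for inhibition, read by MTT assay, with a stated time of 48 h (a higher number here means a weaker inhibitor, a lower number a stronger inhibitor), the lowest of the two numbers measured; compound 1 `Cc1ccc(NC(=O)NC(=O)c2ccc(OCc3ccccc3)cc2)cc1-c1nc2ccccc2[nH]1` gives 16400 nM in this assay. Compound 3 `Cc1ccc(NC(=O)NC(=O)c2ccc(OCc3ccccc3F)cc2)cc1-c1nc2ccccc2[nH]1` differs from compound 2 by 2-fluorophenyl in place of 3-(trifluoromethyl)phenyl on a saturated chain carbon bound to an oxygen on an aromatic ring. Going by the values given here, the only measured step bearing on this site is a 4.7-fold lower number from compound 1 to compound 2 (0.67 log units; beyond the scatter), where trifluoromethyl replaced hydrogen. Removing that trifluoromethyl and offering instead a single fluorine, as 2-fluorophenyl, is expected to give back part of that gain, so the estimated step of a 2.6-fold higher number from compound 2 to compound 3 (0.41 log units; beyond the scatter) points toward a higher number. Compound 3 is expected at 9000 nM, within 3500 nM to 25000 nM.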

Compound 3, half-maximal inhibitory concentration: 760 nM
Estimate against measurement, compound 3: 12-fold (1.07 log units) above; measured number outside the range, below it.
By their numbers in this assay, from the lowest: compound 3; then compound 2; then compound 1.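

At this position a larger group is not needed for the gain: 2-fluorophenyl in place of 3-(trifluoromethyl)phenyl gives a 4.6-fold lower number from compound 2 to compound 3 (0.67 log units; beyond the scatter) on top of the earlier improvement. Measured against the unsubstituted ring, the single fluoro gives a 22-fold lower number from compound 1 to compound 3 (1.33 log units; beyond the scatter) and so outdoes the trifluoromethyl step.

Left open is whether the gain follows the fluorine or its place on the ring, which 3-fluorophenyl and 2-(trifluoromethyl)phenyl would separate, and whether 2-chlorophenyl or 2-methoxyphenyl would do as well. Nothing available here accounts for this order of the compounds.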